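This account rests on a few compounds, and the source may have more. Where it says the series, first, only, none or still open, it means among the compounds named here.

Measured so far in a functional assay on BE(2)-C cells (Homo sapiens) for inhibition, read by MTT assay, with a stated time of 72 h; a higher number here means a weaker inhibitor of growth, a lower number a stronger inhibitor of growth:
compound 1 `O=S(=O)(NCCCCNCc1ccc(Br)cc1)c1cc(C(F)(F)F)cc(C(F)(F)F)c1` gives 2200 nM;
compound 2 `O=S(=O)(NCCCNCc1ccc(Cl)c(Cl)c1)c1cc(C(F)(F)F)cc(C(F)(F)F)c1` gives 2900 nM.

Compound 2 and compound 1 sit within the scatter of each other, the step being a 1.3-fold higher number from compound 1 to compound 2 (0.12 log units; within the scatter), so neither is set apart on these two numbers. Compound 3 `CN(CCCNS(=O)(=O)c1cc(C(F)(F)F)cc(C(F)(F)F)c1)Cc1ccccc1` carries benzyl(methyl)amino in place of (3,4-dichlorobenzyl)amino on a saturated chain carbon, three bonds along the chain from a sulfonamide nitrogen. Among the compounds with values here, the only measured step, from compound 1 to compound 2, also reworked this end of the chain and stayed within the scatter; it is the one guide here. A step in this assay no larger than the scatter, if anything towards a higher number, is therefore expected for compound 3: a 1.2-fold higher number from compound 2 to compound 3 (0.08 log units; within the scatter). Compound 3 is estimated at 3500 nM, range 1500 nM to 8000 nM.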

Compound 3, concentration for 50% growth inhibition: 28000 nM
Beside the measured number, compound 3's estimate is 8.0-fold (0.90 log units) below it; measured number above the stated range.
By their numbers in this assay, from the lowest: compounds 1 and 2 (each within the scatter of the next); then compound 3.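

In this assay this end of the chain proves sensitive, with a 9.7-fold higher number from compound 2 to compound 3 (0.98 log units; beyond the scatter) and a 13-fold higher number from compound 1 to compound 3 (1.10 log units; beyond the scatter) in contrast to the earlier step, which stayed within the scatter. Benzyl(methyl)amino differs from (3,4-dichlorobenzyl)amino in more than one respect: both chlorines go, a methyl sits on the amine nitrogen, and the group's hydrogen-bond donor is lost. Nothing measured here accounts for the rise.

Which of these changes carries the rise stays open. The plain benzylamino group and 3,4-dichlorobenzyl(methyl)amino would separate the chlorines from the methyl.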